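The source may hold more compounds than are shown below. What is called first, only, known or untested is meant among the compounds shown, and "the series" means these compounds.

Measured in a functional assay on MDA-MB-231 cells (Homo sapiens) for antiproliferative activity, read by sulforhodamine B assay, with a stated time of 48 h; on this read-out lower numbers stand for stronger inhibition and higher numbers for weaker inhibition:
- compound 1 `COc1cc(OC)c2sc(-c3ccc(N/C=C\C(=O)c4ccc(OC)c([N+](=O)[O-])c4)c(C)c3)nc2c1`: 10800 nM
- compound 2 `COc1cc(OC)c2sc(-c3ccc(N/C=C\C(=O)c4ccc(OC)c([N+](=O)[O-])c4)cc3)nc2c1`: 12900 nM

The starting point is compound 2 at 12900 nM, a value within the scatter of compound 1, so the pair sets no order. Next is compound 3 `COc1cc(OC)c2sc(-c3ccc(N/C=C\C(=O)c4ccc(OC)c(F)c4)cc3)nc2c1`, which carries fluoro in place of nitro on an aromatic carbon, ortho to a methoxy group and meta to a large group: fluoro in place of nitro on an aromatic carbon. In other words, 4-methoxy-3-nitrophenyl becomes 3-fluoro-4-methoxyphenyl.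

Among the measured compounds shown here, only one measured step is available: a 1.2-fold higher number from compound 1 to compound 2 (0.08 log units; within the scatter). It is a hydrogen in place of methyl and leaves the nitro group untouched, so it bears on this change only indirectly. For the measured compounds named here, no measured pair replaces the nitro group, and the data therefore give no direction for this assay. The expectation stays close to compound 2, with a wide range to cover the missing information. The estimated step is a 1.2-fold lower number from compound 2 to compound 3 (0.07 log units; within the scatter), and no shift beyond the scatter is expected.

For compound 3 the expected value is 11000 nM, with an estimated range of 3000 nM to 40000 nM.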

Compound 3, half-maximal inhibitory concentration: 6700 nM
For compound 3 the middle estimate is 1.6-fold (0.22 log units) above the measured one; low and high end bracket the measured number.
By their numbers in this assay, from the lowest: compounds 3, 1 and 2 (each within the scatter of the next).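

Among the compounds shown here, at the aromatic carbon ortho to a methoxy group and meta to a large group, this assay now gives a first reading of an exchange of the nitro group: fluoro in place of nitro gives a 1.9-fold lower number from compound 2 to compound 3 (0.28 log units; within the scatter) for this change. For the compounds shown here, the only earlier step, a 1.2-fold higher number from compound 1 to compound 2 (0.08 log units; within the scatter) with hydrogen in place of methyl, left the nitro group untouched, whereas here 3 heavy atoms and 2 hydrogen-bond acceptors leave, 1 fluorine atom enters, and the read-out still does not separate the pair. No measurement at hand gives a reason for this outcome.

From the compounds shown here alone, whether any group at this position moves the number beyond the scatter remains open, for instance an amine, a carboxylic acid, a nitrile or plain hydrogen in place of fluoro. Also open, going by these compounds, is whether the hydrogen-for-methyl exchange on the other aromatic ring reads the same with 3-fluoro-4-methoxyphenyl in place of 4-methoxy-3-nitrophenyl, and whether the methoxy group on this ring can itself be exchanged.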